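Swapping the Sulfonyl Group on Compound 2

A few compounds are considered here, and "the series" means these few. Any claim that something is new, unique, unknown or untested is made for them only; others in the source may bear on it.

- Compound 1 `O=C1[C@@H](NS(=O)(=O)c2ccc3c(Cl)c[nH]c3c2)CCN1c1ccc2c(c1)CCNC2`: 6.3 h
- Compound 2 `O=C1[C@@H](NS(=O)(=O)/C=C/c2ccc(Cl)s2)CCN1c1ccc2c(c1F)CCNC2`: 3.3 h

In an in vivo ADME assay on the whole organism (strain Sprague-Dawley) for metabolic stability, with Rattus norvegicus as the target (on this read-out lower numbers stand for a shorter-lived compound and higher numbers for a longer-lived compound), compound 2 gives 3.3 h and compound 1 gives 6.3 h. These two values lie within the usual scatter of each other, so neither compound can be said to stand apart. The next structure is compound 3 `O=C1[C@@H](NS(=O)(=O)c2ccc3c(Cl)c[nH]c3c2)CCN1c1ccc2c(c1F)CCNC2`, which differs from compound 2 at one place: 3-chloro-1H-indol-6-yl in place of 2-(5-chlorothiophen-2-yl)ethenyl on a sulfonyl sulfur. In words, 3-chloro-1H-indol-6-yl replaces 2-(5-chlorothiophen-2-yl)ethenyl on a sulfonyl sulfur. Going by the values given here, no measured pair shows this change alone, so the data give no direct size for it. Among the compounds with values here, the only measured compound carrying 3-chloro-1H-indol-6-yl is compound 1, at 6.3 h, so no step beyond the scatter is expected. The expected move is a 1.4-fold higher number from compound 2 to compound 3 (0.13 log units; within the scatter), an estimate that stays within the scatter. For compound 3 the estimated half-life is 4.5 h, with an expected range of 2.2 h to 9 h.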

Compound 3, half-life: 7.8 h
Beside the measured number, compound 3's estimate is 1.7-fold (0.24 log units) below it, and the stated range covers the measured number.
By their numbers in this assay, from the lowest: compounds 2, 1 and 3 (each within the scatter of the next, the first and the last beyond it).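

On a sulfonyl sulfur whose other neighbour is the sulfonamide nitrogen, 3-chloro-1H-indol-6-yl in place of 2-(5-chlorothiophen-2-yl)ethenyl gives a 2.4-fold higher number from compound 2 to compound 3 (0.37 log units; beyond the scatter) in this assay, the first change in a single place shown to go beyond the scatter, though only modestly. Fluoro in place of hydrogen on an aromatic carbon gives a 1.2-fold higher number from compound 1 to compound 3 (0.09 log units; within the scatter), so this pair shows no clear effect of the fluoro group on half-life. Nothing available explains either result.

This single pair cannot show whether the sulfonyl step keeps its size when hydrogen replaces the fluoro group on that aromatic carbon. Also open, as far as these compounds go, is how half-life would respond to a plain phenyl ring on the sulfonyl sulfur, or to an indolyl group carrying hydrogen in place of its chlorine.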